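Bromo for Methyl on an Aromatic Carbon of Compound 3

The source may report more compounds than this note shows. Statements on the series, on what has been measured and on what is new or still open speak of the compounds shown alone.

Compound 1 `COC(=O)[C@@]1(C)CCC=C2[C@@H]1CC[C@@H](C)[C@]2(C)Cc1c[nH]c2ccccc12`: 5000 nM
Compound 2 `COC(=O)[C@@]1(C)CCC=C2[C@@H]1CC[C@@H](C)[C@]2(C)Cc1c[nH]c2ccc(C)cc12`: 17000 nM
Compound 3 `COC(=O)[C@@]1(C)CCC=C2[C@@H]1CC[C@@H](C)[C@]2(C)Cc1c[nH]c2c(C)cccc12`: 11000 nM

In a functional assay on A549 cells (Homo sapiens) for inhibition, read by sulforhodamine B assay, with a stated time of 48 h (a lower number here means a stronger inhibitor of growth, a higher number a weaker inhibitor of growth), compound 3 gives 11000 nM, the second highest of the three numbers. Compound 2 with 17000 nM lies within the scatter of it, whereas the step of a 2.2-fold higher number from compound 1 to compound 3 (0.34 log units; beyond the scatter) is beyond the scatter. Compound 4 `COC(=O)[C@@]1(C)CCC=C2[C@@H]1CC[C@@H](C)[C@]2(C)Cc1c[nH]c2c(Br)cccc12` differs from compound 3 in one place: bromo in place of methyl on an aromatic carbon. Going by the values given here, no measured step exchanges methyl for bromo, so only the methyl additions a 3.4-fold higher number from compound 1 to compound 2 (0.53 log units; beyond the scatter) and a 2.2-fold higher number from compound 1 to compound 3 (0.34 log units; beyond the scatter) give any footing, and both were modest. With one small group replacing another of the same size, the number for compound 4 is expected to stay close to that of compound 3, a step of no change at the digits printed from compound 3 to compound 4 (within the scatter) that is not beyond the scatter. The estimate for compound 4 is 11000 nM, with a range from 4000 nM to 30000 nM.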

Compound 4, concentration for 50% growth inhibition: 22000 nM
Beside the measured number, compound 4's estimate is 2.0-fold (0.30 log units) below it, and the stated range covers the measured number.
By their numbers in this assay, from the lowest: compound 1; then compounds 3, 2 and 4 (each within the scatter of the next).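

In this assay, bromo in place of methyl on this aromatic carbon gives a 2.0-fold higher number from compound 3 to compound 4 (0.30 log units; within the scatter), so the two groups cannot be told apart here. Against hydrogen, bromo gives a 4.4-fold higher number from compound 1 to compound 4 (0.64 log units; beyond the scatter), so at this position bromo, like methyl in compound 3, leaves a weaker inhibitor of growth than compound 1. Nothing available explains this result.

The compounds shown leave open how an amine or a carboxylic acid on this aromatic carbon would compare with hydrogen. They also leave open how bromo would read on the carbon carrying methyl in compound 2.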